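A few compounds are considered here, and "the series" means these few. Any claim that something is new, unique, unknown or untested is made for them only; others in the source may bear on it.

Measured so far in a functional assay on CHO-K1 cells for agonist activity at Glucose-dependent insulinotropic receptor (Homo sapiens), read by a luciferase reporter, with a stated time of 5 h; on this read-out higher numbers stand for an effect only at larger amounts of compound and lower numbers for an effect already at smaller amounts:
compound 1 `CCOC(=O)N1CCC(Oc2ncnc3c2CCN3c2ccc(S(C)(=O)=O)cc2F)CC1` — 251 nM
compound 2 `CC(C)(C)COC(=O)N1CCC(Oc2ncnc3c2CCN3c2ccc(S(C)(=O)=O)cc2F)CC1` — 39.8 nM
compound 3 `CSC(=O)N1CCC(Oc2ncnc3c2CCN3c2ccc(S(C)(=O)=O)cc2F)CC1` — 251 nM

Compound 3 stands level with compound 1 at the digits given, the two together the highest numbers of the three; its only clear gap is to compound 2, a 6.3-fold higher number from compound 2 to compound 3 (0.80 log units; beyond the scatter).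

Compound 4 `CCSC(=O)N1CCC(Oc2ncnc3c2CCN3c2ccc(S(C)(=O)=O)cc2F)CC1` differs from compound 3 by methyl in place of hydrogen on a saturated chain carbon bound to a sulfur. Among the compounds with values here, two measured steps bear on this. Exchange of the carbamate oxygen chain for the sulfur chain gave no change at the digits printed from compound 1 to compound 3 (within the scatter), so the two heteroatom variants behave alike at this size. Growth of the chain on the oxygen side gave a 6.3-fold lower number from compound 1 to compound 2 (0.80 log units; beyond the scatter), a clearly lower number for the larger group. The step to compound 4 is a far smaller growth, on the sulfur side, and no sulfur homologue has been measured, so its size is uncertain. The expectation for compound 4 is a somewhat lower number than compound 3 in this assay, estimated at a 1.6-fold lower number from compound 3 to compound 4 (0.20 log units; within the scatter), but not beyond the scatter with confidence.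

Compound 4 is estimated at 160 nM, with a range of 63 nM to 400 nM.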

Compound 4, half-maximal effective concentration: 31.6 nM
Estimate against measurement, compound 4: 5.1-fold (0.70 log units) above; the measured number lies below the stated range.
By their numbers in this assay, from the lowest: compounds 4 and 2 (each within the scatter of the next); then compounds 1 and 3 (each within the scatter of the next).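

In this assay, this position responds strongly to a single added carbon on the sulfur side, with a 7.9-fold lower number from compound 3 to compound 4 (0.90 log units; beyond the scatter), so methylsulfanyl and ethylsulfanyl are clearly not equivalent here. The earlier level reading for ethoxy and methylsulfanyl does not carry over to the matched ethyl chains, where the exchange gives a 7.9-fold lower number from compound 1 to compound 4 (0.90 log units; beyond the scatter). Ethylsulfanyl also reaches the level of the much larger neopentyloxy group, with a 1.3-fold lower number from compound 2 to compound 4 (0.10 log units; within the scatter), a step within the scatter that does not separate the two.

As far as these compounds go, whether a longer sulfur chain such as propylsulfanyl or neopentylsulfanyl extends this trend stays open, as does whether an ethylamino group on the carbonyl carbon behaves like ethylsulfanyl. Nothing given here explains why the ethyl chain on sulfur differs so clearly from the methyl chain.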